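Cytotoxicity of Quinoline-Piperazine Isatins in Breast Epithelial Cells

The compounds below may be only part of what the source reports. "The series", "measured", "known", "first", "only" and "open" are said of these compounds alone.

Compound 1 `O=C1C(=O)N(CN2CCN(c3ccnc4cc(Cl)ccc34)CC2)c2ccccc21` gives 71700 nM in an ADME assay on 184B5 cells (Homo sapiens) for cytotoxicity, read by sulforhodamine B assay, with a stated time of 48 h; on this read-out lower numbers stand for stronger inhibition of growth and higher numbers for weaker inhibition of growth.
Compound 2 `O=C1C(=O)N(CN2CCN(c3ccnc4cc(C(F)(F)F)ccc34)CC2)c2ccccc21` gives 43900 nM in this assay.
Compound 3 `NC(=S)N/N=C1/C(=O)N(CN2CCN(c3ccnc4cc(Cl)ccc34)CC2)c2cc(Cl)ccc21` gives 41300 nM in this assay.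

Compound 1 and compound 2 differ by one change, (trifluoromethyl in place of chloro on an aromatic carbon), and this gave a 1.6-fold lower number from compound 1 to compound 2 (0.21 log units; within the scatter). Compound 3 carries a different core; the difference between the core of compound 1 and the core of compound 3 is not broken down here. Compound 4 `NC(=S)N/N=C1/C(=O)N(CN2CCN(c3ccnc4cc(C(F)(F)F)ccc34)CC2)c2cc(Cl)ccc21` has not yet been measured; it differs from compound 3 by the same change, (trifluoromethyl in place of chloro on an aromatic carbon), made at the same place in both pairs.

Because the same change from compound 1 to compound 2 gave a 1.6-fold lower number from compound 1 to compound 2 (0.21 log units; within the scatter), compound 4 is expected to lie close to compound 3, at about a 1.4-fold lower number from compound 3 to compound 4 (0.14 log units; within the scatter) in this assay. The estimate for compound 4 is 30000 nM, expected between 12000 nM and 75000 nM.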

Compound 4, concentration for 50% growth inhibition: 20100 nM
The estimate for compound 4 lay 1.5-fold (0.17 log units) above the measured number; the range from low to high includes it.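

In this assay, trifluoromethyl in place of chloro on an aromatic carbon gave a 2.1-fold lower number from compound 3 to compound 4 (0.31 log units; beyond the scatter). Set beside the earlier step, the change carried from one core to the other without a difference that can be told apart: the same change on two cores in this assay, a 1.6-fold lower number (0.21 log units; within the scatter) from compound 1 to compound 2 and a 2.1-fold lower number (0.31 log units; beyond the scatter) from compound 3 to compound 4, 1.3-fold (0.10 log units) apart, within the scatter of two such steps. Among these compounds, this rests on only two pairs, one of them within the scatter, and it does not show that the step would hold on any further core or why the number moves.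

The compounds shown leave open what a methyl, a methoxy, a nitrile or an amine at this same place would give. They also leave open whether the step persists on cores other than those of compound 1 and compound 3.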